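Swapping the aryl group on the bridging carbon

The compounds below may be only part of what the source reports. "The series", "measured", "known", "first", "only" and "open" are said of these compounds alone.

Measured so far:
Compound 1 `O=C1C(O)=C(C(c2ccccc2)c2c(-c3ccccc3)[nH]c3ccccc23)C(=O)c2ccccc21`: 18800 nM
Compound 2 `COc1ccc(C(C2=C(O)C(=O)c3ccccc3C2=O)c2c[nH]c3ccccc23)cc1Br`: 7320 nM

In a functional assay on HeLa cells (Homo sapiens) for cytotoxicity, read by MTT assay, with a stated time of 48 h (on this read-out lower numbers stand for stronger inhibition and higher numbers for weaker inhibition), compound 2 gives 7320 nM. Compound 2 has the lowest number of the two measured, and its nearest neighbour is compound 1, whose number is higher by a margin that lies beyond the usual scatter. Going by the values given here, compound 1 and compound 2 differ in more than one place, so their two values show only that compound 2 is the stronger of the pair on this read-out.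

Compound 3 `O=C1C(O)=C(C(c2ccc(Cl)cc2)c2c[nH]c3ccccc23)C(=O)c2ccccc21` is not yet measured. It differs from compound 2 in one place: 4-chlorophenyl in place of 3-bromo-4-methoxyphenyl on a saturated chain carbon bound to an aromatic carbon and a double-bonded ring carbon. Among the compounds with values here, no single step of this kind has been measured here, so there is nothing to calibrate the expectation against. The expected step from compound 2 to compound 3 is a 1.2-fold higher number from compound 2 to compound 3 (0.09 log units; within the scatter), a change that may well stay within the scatter. For compound 3 the estimate in this assay is 9000 nM, with a likely range from 3000 nM to 27000 nM.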

Compound 3, half-maximal inhibitory concentration: 37000 nM
For compound 3 the middle estimate is 4.1-fold (0.61 log units) below the measured one; the measured number lies above the stated range.
By their numbers in this assay, from the lowest: compound 2; then compounds 1 and 3 (each within the scatter of the next).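

Going by these compounds alone, this is the first single change measured on the shared core, and it shows that the aryl group on the saturated chain carbon is not interchangeable in this assay: putting 4-chlorophenyl in place of 3-bromo-4-methoxyphenyl gives a 5.1-fold higher number from compound 2 to compound 3 (0.70 log units; beyond the scatter), which means weaker inhibition. The swap alters several things at once, going from 9 heavy atoms to 7, from 1 hydrogen-bond acceptor to 0, and from bromine to chlorine, so this one step cannot separate their contributions. No measurement here accounts for the loss, and its cause stays unknown.

The compounds shown leave open whether the bromine or the methoxy group matters more for the step. They also leave open how an amine or a carboxylic acid on this aryl ring would read in this assay.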